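Adding a phenyl to the benzyl group of compound 1

The compounds below may be only part of what the source reports. "The series", "measured", "known", "first", "only" and "open" are said of these compounds alone.

Compound 1 `Brc1ccc2[nH]c(-c3cncn3Cc3ccccc3)cc2c1`: 11000 nM
Compound 2 `c1ccc(Cn2cncc2-c2cc3ccccc3[nH]2)cc1`: 10800 nM

Of the compounds shown here, two have been tested in an assay on HEK293 cells for inhibition of Indoleamine 2,3-dioxygenase 1 (Homo sapiens), with a stated time of 30 min; a lower number here means that less compound is needed, a higher number that more compound is needed for the effect. Compound 1 `Brc1ccc2[nH]c(-c3cncn3Cc3ccccc3)cc2c1` gives 11000 nM, the highest of the two numbers, but compound 2 `c1ccc(Cn2cncc2-c2cc3ccccc3[nH]2)cc1` gives 10800 nM, and the step of a 1.0-fold lower number from compound 1 to compound 2 (0.01 log units; within the scatter) is within the scatter, so the two cannot be told apart. That step, hydrogen in place of bromo on an aromatic carbon, is the only measured one, and it touches a different part of the molecule.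

Compound 3 `Brc1ccc2[nH]c(-c3cncn3Cc3ccc(-c4ccccc4)cc3)cc2c1` has not been measured. Against compound 1 the change is phenyl in place of hydrogen on an aromatic carbon. For the measured compounds named here, no measured step bears on this change: the one step that exists leaves the benzyl group untouched. Any expectation for compound 3 therefore rests only on the two numbers, which sit close together, and on the fact that a phenyl is a sizeable addition.

Compound 3 is therefore expected to land near compound 1, with the step of a 1.4-fold lower number from compound 1 to compound 3 (0.14 log units; within the scatter) as the estimate, and the estimate for compound 3 in this assay is 8000 nM, within 2000 nM to 30000 nM.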

Compound 3, half-maximal effective concentration: 3090 nM
Compound 3: middle estimate off by 2.6-fold (0.41 log units), on the high side, within the range that was stated.
By their numbers in this assay, from the lowest: compound 3; then compounds 2 and 1 (each within the scatter of the next).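

In this assay, the benzyl group proves to be a place where a change can move the number beyond the scatter, whereas removing the bromo from the core gave only a 1.0-fold lower number from compound 1 to compound 2 (0.01 log units; within the scatter) and so showed no measurable effect. Phenyl in place of hydrogen on an aromatic carbon of the benzyl group, para to a large group, gives a 3.6-fold lower number from compound 1 to compound 3 (0.55 log units; beyond the scatter) and this counts as a modest step, so a sizeable addition of one more six-membered aromatic ring is accepted here and comes with less compound being needed for the effect. The step describes what happens in this assay, but no measurement at hand accounts for why the number falls.

The compounds shown leave open whether the phenyl itself matters or whether other groups at this same place, such as a methyl, an amine or a carboxylic acid, would give a similar step. They also leave open whether phenyl on the benzyl group of compound 2, which has hydrogen in place of the bromo, would lower the number by a similar amount.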